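This account rests on a few compounds, and the source may have more. Where it says the series, first, only, none or still open, it means among the compounds named here.

Compound 1 `O=C(NOCc1ccccc1F)c1cn(-c2ccccc2)nc1-c1ccccc1` gives 5940 nM in a functional assay on A549 cells (Homo sapiens) for antiproliferative activity, read by MTT assay, with a stated time of 48 h, in the presence of a further agent that is not named here; a higher number here means a weaker inhibitor of growth, a lower number a stronger inhibitor of growth. Compound 2 `O=C(NOCc1ccccc1Cl)c1cn(-c2ccccc2)nc1-c1ccccc1` differs from it by chloro in place of fluoro on an aromatic carbon, and in this assay compound 2 gives 10300 nM, a step of a 1.7-fold higher number from compound 1 to compound 2 (0.24 log units; within the scatter). Compound 3 `Cc1ccc(-c2nn(-c3ccccc3)cc2C(=O)NOCc2ccccc2F)cc1` differs from compound 1 by methyl in place of hydrogen on an aromatic carbon, and in this assay compound 3 gives 260 nM, a step of a 23-fold lower number from compound 1 to compound 3 (1.36 log units; beyond the scatter). Compound 4 `Cc1ccc(-c2nn(-c3ccccc3)cc2C(=O)NOCc2ccccc2Cl)cc1` has not yet been measured; it differs from compound 3 by chloro in place of fluoro on an aromatic carbon, the same change that separates compound 1 from compound 2, at the same place. For compound 4 a step of a 1.6-fold higher number from compound 3 to compound 4 (0.21 log units; within the scatter) is expected in this assay, set beside the earlier step, because a 1.7-fold higher number from compound 1 to compound 2 (0.24 log units; within the scatter) lay within the scatter. Compound 4 is therefore estimated at 420 nM, with a range from 200 nM to 900 nM.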

Compound 4, concentration for 50% growth inhibition: 380 nM
Beside the measured number, compound 4's estimate is 1.1-fold (0.04 log units) above it; measured number inside the range.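

In this assay, chloro in place of fluoro gives a 1.5-fold higher number from compound 3 to compound 4 (0.16 log units; within the scatter), and this change carries from the core of compound 1 to the core of compound 3 with no difference beyond the scatter: the same change on two cores in this assay, a 1.7-fold higher number (0.24 log units; within the scatter) from compound 1 to compound 2 and a 1.5-fold higher number (0.16 log units; within the scatter) from compound 3 to compound 4, 1.2-fold (0.07 log units) apart, within the scatter of two such steps. Methyl in place of hydrogen gives a 27-fold lower number from compound 2 to compound 4 (1.43 log units; beyond the scatter), and this large step holds with either 2-fluorobenzyl or 2-chlorobenzyl present: the same change on two cores in this assay, a 23-fold lower number (1.36 log units; beyond the scatter) from compound 1 to compound 3 and a 27-fold lower number (1.43 log units; beyond the scatter) from compound 2 to compound 4, 1.2-fold (0.07 log units) apart, within the scatter of two such steps. The two changes thus behave independently across these four compounds, but this does not show that they would do so on any other core, or that chloro and fluoro differ at all in this assay.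

The compounds shown leave open whether a methoxy group or an amine in place of the methyl would give a step of similar size. They also leave open whether bromo in place of chloro would carry across the two cores in the same way.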